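Ethoxycarbonyl in Place of Acetyl on a Nitro Analogue

A few compounds are considered here, and "the series" means these few. Any claim that something is new, unique, unknown or untested is made for them only; others in the source may bear on it.

Three measured compounds share one core and differ only in the substituent on an aromatic carbon. Compound 1 `CC(=O)c1nn(-c2ccc(C)cc2)/c(=N/c2nc(-c3c(C)n(C)n(-c4ccccc4)c3=O)cs2)s1` gives 56800 nM in a functional assay on MCF7 cells (Homo sapiens) for cytotoxicity, read by sulforhodamine B assay, with a stated time of 72 h; a higher number here means a weaker inhibitor, a lower number a stronger inhibitor. Compound 2 `COc1ccc(-n2nc(C(C)=O)s/c2=N\c2nc(-c3c(C)n(C)n(-c4ccccc4)c3=O)cs2)cc1` gives 64500 nM in this assay, and the step of a 1.1-fold higher number from compound 1 to compound 2 (0.06 log units; within the scatter) stays within the scatter. Compound 3 `CC(=O)c1nn(-c2ccc([N+](=O)[O-])cc2)/c(=N/c2nc(-c3c(C)n(C)n(-c4ccccc4)c3=O)cs2)s1` is reported in this assay only as a limit, > 100000 nM, and not as a number (the limit of > 100000 nM in this assay, at which 1 of the 3 values shown sits). The steps of an at least 1.7-fold higher number from compound 1 to compound 3 (0.24 log units; that floor lies within the scatter) and an at least 1.5-fold higher number from compound 2 to compound 3 (0.19 log units; that floor lies within the scatter) are floors that also lie within the scatter, so compound 3 stands at the limit of the numbers shown without a measured value of its own.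

Compound 4 `CCOC(=O)c1nn(-c2ccc([N+](=O)[O-])cc2)/c(=N/c2nc(-c3c(C)n(C)n(-c4ccccc4)c3=O)cs2)s1` differs from compound 3 by ethoxy in place of methyl on a carbonyl carbon. None of the three measured steps touches a carbonyl carbon; all concern the substituent on an aromatic carbon, and none of them left the scatter. Among the measured compounds shown here, no measured step therefore offers a direction in this assay for this change. The expected step is a step that the limit leaves unreadable from compound 3 to compound 4, nothing beyond the scatter. Compound 4 is estimated at 150000 nM, with a range from 60000 nM to 400000 nM, and is expected to be reported again only as a limit.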

Compound 4, half-maximal inhibitory concentration: 10000 nM
Beside the measured number, compound 4's estimate is 15-fold (1.18 log units) above it, outside the stated range (below it).
By their numbers in this assay, from the lowest: compound 4; then compounds 1 and 2 (each within the scatter of the next). At a limit, above all of these: compound 3.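

The step of an at least 10-fold lower number from compound 3 to compound 4 (1.00 log units; beyond the scatter) in this assay is the first one shown whose size lies beyond the scatter, and it arises on a carbonyl carbon, not on an aromatic carbon. The exchanges among methyl, methoxy and nitro on the aromatic carbon had shown no step beyond the scatter, so this position is the first shown to move the number, at least on the nitro analogue. Compound 3 is reported only as a limit, so the size of this step is a floor and the full change remains unknown: the limit of > 100000 nM in this assay, at which 1 of the 4 values shown sits.

The compounds shown leave open whether acetyl to ethoxycarbonyl has a similar effect with methyl or methoxy on the aromatic carbon. They also leave open what a carboxylic acid, an amide or a longer alkoxy chain would do on the same carbonyl carbon.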